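Adding a Phenyl to the Piperidine Amide of Compound 3

This account rests on a few compounds, and the source may have more. Where it says the series, first, only, none or still open, it means among the compounds named here.

The three compounds share one core and differ only in the amide portion. In a functional assay on MCF7 cells (Homo sapiens) for inhibition, read by MTT assay, with a stated time of 48 h (on this read-out higher numbers stand for weaker inhibition and lower numbers for stronger inhibition), compound 1 `COc1ccc(/C=C/c2cc(OC)cc(OC)c2/C=C/C(=O)NC2CC2)cc1` gives 3940 nM, compound 2 `COc1ccc(/C=C/c2cc(OC)cc(OC)c2/C=C/C(=O)N2CCC(Cl)CC2)cc1` gives 4950 nM, and compound 3 `COc1ccc(/C=C/c2cc(OC)cc(OC)c2/C=C/C(=O)N2CCCCC2)cc1` gives 6050 nM. The three numbers sit close together: a 1.5-fold higher number from compound 1 to compound 3 (0.19 log units; within the scatter), a 1.2-fold higher number from compound 2 to compound 3 (0.09 log units; within the scatter), and a 1.3-fold higher number from compound 1 to compound 2 (0.10 log units; within the scatter). So compound 3 cannot be separated from the other two on these numbers.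

Compound 4 `COc1ccc(/C=C/c2cc(OC)cc(OC)c2/C=C/C(=O)N2CCC(c3ccccc3)CC2)cc1` takes the next step from compound 3: phenyl in place of hydrogen on a saturated ring carbon. Among the measured compounds shown here, the one measured step that touches the same position is the one from compound 2 to compound 3, where a chloro gave way to hydrogen, and that step stayed within the scatter. Exchanging the whole amine portion, as in the steps from compound 1, also moved the numbers only within the scatter. A phenyl is larger than any group tried there, so the expectation is a step of similar small size, most likely none beyond the scatter: the step from compound 3 to compound 4 is estimated at a 1.2-fold lower number from compound 3 to compound 4 (0.08 log units; within the scatter). For compound 4 the expected value in this assay is 5000 nM, with a range from 2000 nM to 15000 nM.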

Compound 4, half-maximal inhibitory concentration: 4230 nM
The estimate for compound 4 lay 1.2-fold (0.07 log units) above the measured number; the measured number falls inside the stated range.
By their numbers in this assay, from the lowest: compounds 1, 4, 2 and 3 (each within the scatter of the next).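

Putting a phenyl, with its 6 heavy atoms, on this saturated ring carbon, three ring bonds from the ring nitrogen, gives a 1.4-fold lower number from compound 3 to compound 4 (0.16 log units; within the scatter) in this assay, so even this much larger addition leaves the number within the scatter. Exchanging chloro for phenyl gives a 1.2-fold lower number from compound 2 to compound 4 (0.07 log units; within the scatter), and exchanging cyclopropylamino for 4-phenylpiperidin-1-yl gives a 1.1-fold higher number from compound 1 to compound 4 (0.03 log units; within the scatter). Hydrogen, chloro and phenyl therefore cannot be told apart at this position on these numbers, and nothing at hand offers an explanation for this.

The compounds shown leave open whether an amine, a carboxylic acid or a longer chain on the same ring carbon would move the number beyond the scatter. They also leave open whether a hydroxyl on the added phenyl would do so.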